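Notes on the amide-nitrogen substituent in this series

This account rests on a few compounds, and the source may have more. Where it says the series, first, only, none or still open, it means among the compounds named here.

Measured so far:
compound 1 `C=CCc1cc(-c2sc(NC(=O)C(C)(C)C)nc2C)nn1C(=O)Nc1ccc(OC)cc1`, in an assay on cells with Cystic fibrosis transmembrane conductance regulator variant F508del (Homo sapiens) as the target, read by fluorescence, with stated times of 24 h and 30 min (a lower number here means that less compound is needed, a higher number that more compound is needed for the effect), compound 1 gives 933 nM
compound 2 `COc1ccc(NC(=O)n2nc(-c3sc(NC(=O)C(C)(C)C)nc3C)cc2Cc2cc(Cl)ccc2OC)cc1`, compound 2 gives 1000 nM

Going by the values given here, compound 2 carries the higher of the two numbers, but its only neighbour is compound 1, and a 1.1-fold higher number from compound 1 to compound 2 (0.03 log units; within the scatter) lies within the scatter, so the two cannot be ordered; the pair is best read as one level.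

Compound 3 `COc1ccc(Cl)cc1Cc1cc(-c2sc(NC(=O)C(C)(C)C)nc2C)nn1C(=O)NCCO` is not yet measured. It differs from compound 2 in a single place: 2-hydroxyethyl in place of 4-methoxyphenyl on an amide-type nitrogen. Among the compounds with values here, no measured step touches this position. Within the data shown here, the one step available, a 1.1-fold higher number from compound 1 to compound 2 (0.03 log units; within the scatter), alters a different part of the molecule and leaves the number essentially unmoved, so it carries no information about the amide nitrogen. Nothing in the measured pair shows how a change at the amide nitrogen moves this assay, and no direction beyond the scatter can be derived.

The working expectation for compound 3 is therefore 1000 nM, with a wide range from 250 nM to 4000 nM. The expected step is thus no change at the digits printed from compound 2 to compound 3 (within the scatter), a placeholder rather than a prediction of movement.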

Compound 3, half-maximal effective concentration: 3020 nM
For compound 3 the middle estimate is 3.0-fold (0.48 log units) below the measured one, within the range that was stated.
By their numbers in this assay, from the lowest: compounds 1 and 2 (each within the scatter of the next); then compound 3.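

Notes on the amide nitrogen: in this assay the change to 2-hydroxyethyl in place of 4-methoxyphenyl gives a 3.0-fold higher number from compound 2 to compound 3 (0.48 log units; beyond the scatter) and so shows that the number responds to the group at this position, which the earlier pair could not show. The only other step, a 1.1-fold higher number from compound 1 to compound 2 (0.03 log units; within the scatter), concerns a different part of the molecule and stays within the scatter, so the amide nitrogen is the only position shown here where a single change moves the number beyond it. The change removes the six-membered aromatic ring and brings in a hydrogen-bond donor at the same time, and nothing on hand gives a reason for the step.

The compounds shown do not separate the loss of the ring from the gain of the hydroxyl: a plain phenyl, a benzyl or a 2-methoxyethyl group on this nitrogen would help to tell these apart. From the compounds shown here alone, it also remains open whether an open chain here can match the 4-methoxyphenyl level at all, for instance a longer chain, a chain ending in an amine or one ending in a carboxylic acid.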